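Adding a methoxy group to compound 3

This account rests on a few compounds, and the source may have more. Where it says the series, first, only, none or still open, it means among the compounds named here.

Growth inhibition values in a functional assay on K562 cells (Homo sapiens) for inhibition, read by sulforhodamine B assay, with a stated time of 48 h (on this read-out higher numbers stand for weaker inhibition of growth and lower numbers for stronger inhibition of growth), for these compounds
Compound 1 `CCOC(=O)c1nn(-c2ccccc2)c(-c2ccc(OC)cc2)c1CNC(C)(C)C` gives 66600 nM; 29800 nM (2 entries)
Compound 2 `CC(C)(C)NCc1c(C(=O)O)nn(-c2ccccc2)c1-c1ccc(Cl)cc1` gives 364000 nM
Compound 3 `CC(C)(C)NCc1c(C(=O)O)nn(-c2ccccc2)c1-c1ccccc1` gives > 716000 nM as a limit, not a number
Compound 4 `COc1ccc(-c2c(CNC(C)(C)C)c(C(=O)O)nn2-c2ccccc2)cc1` is not yet measured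

From the compounds shown here alone, compound 3 stands only at a limit, so its true value stays open. The change to compound 4 is methoxy in place of hydrogen on an aromatic carbon with methoxy in place of hydrogen on an aromatic carbon, para to a large group. Going by the values given here, the one measured step that bears on this also exchanges a group on an aromatic carbon, here hydrogen in place of chloro, an at least 1.9-fold higher number from compound 2 to compound 3 (0.29 log units; that floor lies within the scatter), so in this assay a small move towards a lower number is expected, perhaps none beyond the scatter. An estimated at least 1.5-fold lower number from compound 3 to compound 4 (0.20 log units; that floor lies within the scatter) is what this suggests. For compound 4 the expected value is 450000 nM, with an estimated range of 180000 nM to 1000000 nM on this thin evidence.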

Compound 4, concentration for 50% growth inhibition: > 659000 nM
Compound 4: a limit, no number; the forecaster's own chance of this, stated with the estimate: 40%; middle value at least 1.4-fold (0.16 log units) away from the limit.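

In this assay, compound 4 gives only a limit, > 659000 nM, not a number. Compound 3 also gives only a limit, > 716000 nM, so the step between these two cannot be read. Exchanging chloro for methoxy at this position gives an at least 1.8-fold higher number from compound 2 to compound 4 (0.25 log units; that floor lies within the scatter), which leaves chloro as the only group at this position with a measured number among the carboxylic acids shown.

From the compounds shown here alone, whether methoxy changes growth inhibition at all here remains open. So does what an amine or a longer chain such as ethoxy would do at this position.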